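The compounds below may be only part of what the source reports. "The series", "measured", "known", "first", "only" and "open" are said of these compounds alone.

Compound 1 `COc1cc(-c2cc(-c3ccc(Br)cc3)nc(-c3ccccc3)n2)cc(OC)c1OC` gives 3170 nM in a functional assay on HT-29 cells (Homo sapiens) for inhibition, read by MTT assay, with a stated time of 48 h; a higher number here means a weaker inhibitor, a lower number a stronger inhibitor.
Compound 2 `COc1cc(-c2cc(-c3ccccc3)nc(-c3ccccc3)n2)cc(OC)c1OC` gives 7930 nM.
Compound 3 `COc1cc(-c2cc(-c3cccs3)nc(-c3ccccc3)n2)cc(OC)c1OC` reaches only a limit of the assay, > 25000 nM.

Compound 1 stands lowest of the two numbers shown; the nearest is a 2.5-fold higher number from compound 1 to compound 2 (0.40 log units; beyond the scatter). The value of compound 3 is a limit, not a number (the limit of > 25000 nM in this assay, at which 1 of the 3 values shown sits). Compound 4 `COc1cc(-c2cc(-c3ccc(C)cc3)nc(-c3ccccc3)n2)cc(OC)c1OC` differs from compound 1 in one place: methyl in place of bromo on an aromatic carbon. For the measured compounds named here, no measured step exchanges one group on that ring for another; the closest is a 2.5-fold higher number from compound 1 to compound 2 (0.40 log units; beyond the scatter), where a group leaves, and an at least 7.8-fold higher number from compound 1 to compound 3 (0.89 log units; beyond the scatter), where the whole ring is exchanged. A small step is therefore expected, a 1.4-fold higher number from compound 1 to compound 4 (0.15 log units; within the scatter), near the scatter. Compound 4 is estimated at 4500 nM, between 1500 nM and 15000 nM.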

Compound 4, half-maximal inhibitory concentration: > 25000 nM
Compound 4: a limit, no number (the forecaster's own chance of this, stated with the estimate: 5%); middle value at least 5.5-fold (0.74 log units) away from the limit.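

Exchanging bromo for methyl swaps one heavy atom for one heavy atom, yet in this assay it gives an at least 7.8-fold higher number from compound 1 to compound 4 (0.89 log units; beyond the scatter). Methyl also compares poorly with hydrogen at this place, with an at least 3.1-fold higher number from compound 2 to compound 4 (0.49 log units; beyond the scatter), so of the three groups tried here only bromo and hydrogen give readable numbers. Compound 4 gives only a limit, as compound 3 does, and the step between them cannot be read: the limit of > 25000 nM in this assay, at which 2 of the 4 values shown sit.

The compounds shown leave open whether a chloro, a methoxy or an amine at this place would give a readable number. On these data alone, how much weaker compound 4 really is also stays unknown.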